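A few compounds are considered here, and "the series" means these few. Any claim that something is new, unique, unknown or untested is made for them only; others in the source may bear on it.

Measured so far:
- compound 1, `COc1ccc(C2=NN(c3ccccc3)C(c3ccc(C)cc3)C2S(=O)(=O)CC2=NCCO2)cc1`: 64.9%
- compound 2, `O=S(=O)(CC1=NCCO1)c1n[nH]cc1-c1ccc(Cl)cc1`: "not active" (no number reported)
- compound 3, `COc1ccc(C2=NN(c3ccccc3)C(c3ccc(C)cc3)C2S(=O)(=O)CC2=NCCS2)cc1`: 44.9%

In a functional assay, read by Griess assay, with a stated time of 150 min, tested at 75 ug/mL (on this read-out higher numbers stand for a stronger effect at the one concentration tested and lower numbers for a weaker effect), compound 1 gives 64.9%. Compound 2 is reported in this assay only as "not active" (no number reported), with no number attached. Compound 3 gives 44.9% in this assay.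

The difference between the cores of compound 1 and compound 2 is not broken down here. The step from compound 1 to compound 3 is a group of 5 heavy atoms (3 carbon, 1 nitrogen, 1 sulfur; one five-membered non-aromatic ring with 2 hetero atoms) in place of a group of 5 heavy atoms (3 carbon, 1 nitrogen, 1 oxygen; one five-membered non-aromatic ring with 2 hetero atoms), on a saturated chain carbon bound to a sulfonyl sulfur; it gave a number 20 percentage points lower from compound 1 to compound 3 (beyond the scatter).

Not yet measured is compound 4, `O=S(=O)(CC1=NCCS1)c1n[nH]cc1-c1ccc(Cl)cc1`. Compound 4 differs from compound 2 by a group of 5 heavy atoms (3 carbon, 1 nitrogen, 1 sulfur; one five-membered non-aromatic ring with 2 hetero atoms) in place of a group of 5 heavy atoms (3 carbon, 1 nitrogen, 1 oxygen; one five-membered non-aromatic ring with 2 hetero atoms), on a saturated chain carbon bound to a sulfonyl sulfur, the same change as from compound 1 to compound 3, at the same place.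

For compound 4 in this assay the expectation rests on two things: compound 2 is reported as "not active" (no number reported), and the same change from compound 1 to compound 3 gave a number 20 percentage points lower from compound 1 to compound 3 (beyond the scatter), a downward step. Nothing in the series points upward for this change. Compound 4 is therefore expected to give 8% in this assay, estimated within 0% to 25%, and it may well be reported only as not active.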

Compound 4, a percentage reported as activity, at one concentration (the size of the read-out at that concentration, not a potency): "not active" (no number reported)
Nothing numeric was reported for compound 4, so the estimate cannot be set against anything.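

In this assay compound 2 reads "not active" (no number reported) and compound 4 reads "not active" (no number reported) with no number on either side, and no step can be read between them. The compounds shown leave open whether the change seen on the core of compound 1 has any size on the core of compound 2. No measured evidence bears on this result.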